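This account rests on a few compounds, and the source may have more. Where it says the series, first, only, none or still open, it means among the compounds named here.

Measured compounds:

Compound 1, `O=[N+]([O-])c1cccc(/N=N/N2CCCCC2)c1`, gives in an ADME assay on BHK-21 cells (Mesocricetus auratus) for cytotoxicity, read by MTT assay, with a stated time of 96 h (a higher number here means that more compound is tolerated, a lower number that less compound is tolerated), only a limit, > 100000 nM.
Compound 2, `CN(/N=N/c1ccccc1)c1ccccc1`, gives in this assay only a limit, > 100000 nM.
Compound 3, `Cc1ccc(/N=N/N(C)c2ccccc2)cc1`, gives in this assay only a limit, > 100000 nM.

Compound 2 therefore stands at the edge of what this assay can report, and the two other measured values stand there as well: the limit of > 100000 nM in this assay, at which 3 of the 3 values shown sit. For the measured compounds named here, the one measured step between neighbours, a step that the two limits leave unreadable from compound 2 to compound 3, cannot be read in size because both ends are limits.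

The unmeasured compound 4, `CN(C)CCCN(/N=N/c1ccccc1)c1ccccc1`, differs from compound 2 by 2-(dimethylamino)ethyl in place of hydrogen on a saturated chain carbon bound to a nitrogen on an aromatic ring. Going by the values given here, no measured step touches this kind of change, and the one step that exists is unreadable, so no direction or size of change beyond the scatter can be read from the data for compound 4.

The expectation is that compound 4 also sits at the limit of this assay, with an estimated value of 100000 nM and a range from 30000 nM to 300000 nM. The step from compound 2 that this estimate means is expected to be a number no higher from compound 2 to compound 4 (the limit leaves the size open).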

Compound 4, half-maximal cytotoxic concentration: 50000 nM
For compound 4 the middle estimate is 2.0-fold (0.30 log units) above the measured one; the range from low to high includes it.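

Compound 4 is the only compound shown with a number rather than a limit, so a change at this place, on a saturated chain carbon bound to a nitrogen on an aromatic ring, can bring a value within what this assay can read. Read one bond further out as methyl to 3-(dimethylamino)propyl, the change gives an at least 2.0-fold lower number from compound 2 to compound 4 (0.30 log units; that floor lies within the scatter). Going by these compounds, the true size of this step stays open because compound 2 has only a limit as its value: the limit of > 100000 nM in this assay, at which 3 of the 4 values shown sit.

The compounds shown leave open whether the result depends on the amine at the end of the chain or on the chain itself. A chain of the same length ending in a hydroxyl group, or a shorter chain ending in the same dimethylamino group, would help to separate the two.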